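Thiophene Analogue of a Chalcone Series: Cytotoxicity Expectation

The source may report more compounds than this note shows. Statements on the series, on what has been measured and on what is new or still open speak of the compounds shown alone.

In an ADME assay on L929 cells (Mus musculus) for cytotoxicity, read by resazurin assay, with a stated time of 72 h (on this read-out lower numbers stand for stronger inhibition and higher numbers for weaker inhibition), three compounds have been measured so far:
compound 1 `O=C(/C=C/c1ccc2c(c1)B(O)OC2)c1ccc(Br)cc1` gives > 10 ug/mL, a limit of the assay.
compound 2 `Cc1cccc(C(=O)/C=C/c2ccc3c(c2)B(O)OC3)c1` gives 8.56 ug/mL.
compound 3 `O=C(/C=C/c1ccc2c(c1)B(O)OC2)c1ccccc1O` gives > 10 ug/mL, a limit of the assay.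

Compound 3 thus stands at the limit of > 10 ug/mL in this assay, at which 2 of the 3 values shown sit, with no number of its own. Compound 4 `O=C(/C=C/c1ccc2c(c1)B(O)OC2)c1cccs1` differs from it by thiophen-2-yl in place of 2-hydroxyphenyl on a carbonyl carbon. The steps that touch compound 3 are a step that the two limits leave unreadable from compound 1 to compound 3 and an at least 1.1-fold higher number from compound 2 to compound 3 (0.06 log units; that floor lies within the scatter), and neither involves thiophen-2-yl, so the new change cannot be read from any measured step. Compound 4 is therefore expected to stay close to the limit, with a step of a number no higher from compound 3 to compound 4 (the limit leaves the size open) in this assay. The estimate for compound 4 is 10 ug/mL, ranging from 5 ug/mL to 20 ug/mL.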

Compound 4, half-maximal inhibitory concentration: > 10 ug/mL
Compound 4 was reported as a limit; the forecaster's own chance of this, stated with the estimate: 55%; the middle value lies on the limit itself.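

With thiophen-2-yl on the carbonyl carbon, the five-membered aromatic ring leaves the read-out in this assay where the 4-bromophenyl and 2-hydroxyphenyl compounds stand, at the limit of the assay: the limit of > 10 ug/mL in this assay, at which 3 of the 4 values shown sit. For the compounds shown here, the one readable step is an at least 1.1-fold higher number from compound 2 to compound 4 (0.06 log units; that floor lies within the scatter) and so shows no change beyond the scatter. The steps from compound 1 and from compound 3 to compound 4 cannot be read.

The compounds shown leave open how far compound 1, compound 3 and compound 4 lie past that limit. They also leave open whether an amine or a carboxylic acid in this place would give a number inside the readable range.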